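From Chloro to Fluoro on a Silent Scaffold

A few compounds are considered here, and "the series" means these few. Any claim that something is new, unique, unknown or untested is made for them only; others in the source may bear on it.

Compound 1 `Fc1cc(Cl)ccc1N1CCN(Cc2ccn3c(CC4CC4)nnc3c2C(F)(F)F)CC1` was tested in a functional assay on HEK293 cells for agonist activity at metabotropic glutamate receptor 5 (Homo sapiens), read by a luciferase reporter and cAMP accumulation; on this read-out lower numbers stand for an effect already at smaller amounts and higher numbers for an effect only at larger amounts of compound. In this assay compound 1 gives > 10000 nM, which is a limit of the assay rather than a measured number. Compound 2 `Fc1ccc(N2CCN(Cc3cc(C(F)(F)F)cn4c(CC5CC5)nnc34)CC2)c(F)c1` likewise gives > 10000 nM in this assay, again a limit. Compound 3 `Fc1ccc(C2CCN(Cc3ccn4c(CC5CC5)nnc4c3C(F)(F)F)CC2)c(F)c1` also gives > 10000 nM in this assay, a limit as well. All three measured compounds therefore sit at the limit of > 10000 nM in this assay, at which 3 of the 3 values shown sit, and compound 1 stands at the same limit as the other two, with no number that could set it apart.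

Compound 4 `Fc1ccc(N2CCN(Cc3ccn4c(CC5CC5)nnc4c3C(F)(F)F)CC2)c(F)c1` has not yet been measured. It differs from compound 1 by a single exchange: fluoro in place of chloro on an aromatic carbon. Compound 2 and compound 3 already carry a 2,4-difluorophenyl group and both sit at the limit.

Within the data shown here, with no measured step to lean on and every neighbour at the limit, the step from compound 1 to compound 4 is expected to be a step that the limit leaves unreadable from compound 1 to compound 4, which is nothing beyond the scatter. Compound 4 is therefore expected to give 20000 nM in this assay, between 8000 nM and 100000 nM, and most likely to be reported again only as a limit.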

Compound 4, half-maximal effective concentration: > 8000 nM
Compound 4: only a limit was reported; the forecaster's own chance of this, stated with the estimate: 90%; the middle value lies beyond the limit too.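

Compound 1 and compound 4 are both reported only as limits, and the step between them, fluoro in place of chloro, cannot be read. The compounds shown leave open whether any of them gives a measurable effect in this assay and whether this exchange changes it.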